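A few compounds are considered here, and "the series" means these few. Any claim that something is new, unique, unknown or untested is made for them only; others in the source may bear on it.

Among the compounds with values here, in a functional assay on DU-145 cells (Homo sapiens) for inhibition, read by trypan blue exclusion, with a stated time of 72 h (on this read-out lower numbers stand for stronger inhibition and higher numbers for weaker inhibition), compound 1 `Cn1c(=O)c(S(=O)(=O)c2ccc(F)cc2F)cc2cnc(Nc3ccc4[nH]c(C(=O)O)cc4c3)nc21` gives 10000 nM, the higher of the two numbers so far. Compound 2 `Cn1c(=O)c(S(=O)(=O)Cc2ccc(F)cc2F)cc2cnc(Nc3ccc4[nH]ccc4c3)nc21` gives 1000 nM, a gap beyond the scatter, and it differs from compound 1 in more than one place. Compound 3 `Cn1c(=O)c(S(=O)(=O)c2ccc(F)cc2F)cc2cnc(Nc3ccc4occc4c3)nc21` is still unmeasured. It carries 1-benzofuran-5-yl in place of 2-carboxy-1H-indol-5-yl on a nitrogen on an aromatic ring. Within the data shown here, no measured pair isolates this change, so the expectation rests loosely on compound 2 at 1000 nM, which also has no carboxy group. A step to a lower number, meaning stronger inhibition, is expected, estimated as a 10-fold lower number from compound 1 to compound 3 (1.00 log units; beyond the scatter). Compound 3 is expected near 1000 nM, within an estimated range of 200 nM to 5000 nM.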

Compound 3, half-maximal inhibitory concentration: 15000 nM
The estimate for compound 3 lay 15-fold (1.18 log units) below the measured number, outside the stated range (above it).
By their numbers in this assay, from the lowest: compound 2; then compounds 1 and 3 (each within the scatter of the next).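

In this assay, putting 1-benzofuran-5-yl in place of 2-carboxy-1H-indol-5-yl on this nitrogen gives a 1.5-fold higher number from compound 1 to compound 3 (0.18 log units; within the scatter). Two different bicyclic groups, one with a carboxy group and one without, therefore cannot be told apart on this read-out, and both leave compound 1 and compound 3 equally weak in this comparison. Nothing available explains this result. Still open, as far as these compounds go, is whether any group on this nitrogen can shift the number on the core of compound 1, for example a phenyl ring carrying an amine or a methyl ester.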